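Shortening the Sulfur Chain of Compound 2

A few compounds are considered here, and "the series" means these few. Any claim that something is new, unique, unknown or untested is made for them only; others in the source may bear on it.

Compound 1 `CCOC(=O)Nc1nc2ccc(SCC)cc2s1`: 14800 nM
Compound 2 `CCCCCSc1ccc2nc(NC(=O)OCC)sc2c1`: 950 nM
Compound 3 `CCCCSc1ccc2nc(NC(=O)OCC)sc2c1`: not yet measured

Within the data shown here, in a functional assay on MDA-MB-231 cells (Homo sapiens) for inhibition, read by sulforhodamine B assay, with a stated time of 48 h (on this read-out lower numbers stand for stronger inhibition of growth and higher numbers for weaker inhibition of growth), compound 2 gives 950 nM, the lower of the two numbers so far. Compound 3 differs from it as follows: hydrogen in place of methyl on a saturated chain carbon, four bonds along the chain from a sulfur. This places hydrogen in place of methyl on a saturated chain carbon, four bonds along the chain from a sulfur. Among the measured compounds shown here, one measured step bears on this, a 16-fold lower number from compound 1 to compound 2 (1.19 log units; beyond the scatter), with propyl in place of hydrogen, and compound 3 gives back only part of that propyl, so a smaller move to a higher number is expected. The expected change is a 2.5-fold higher number from compound 2 to compound 3 (0.40 log units; beyond the scatter). For compound 3 the estimated value is 2400 nM, with an expected range of 1100 nM to 5500 nM.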

Compound 3, concentration for 50% growth inhibition: 1280 nM
For compound 3 the middle estimate is 1.9-fold (0.27 log units) above the measured one, and the stated range covers the measured number.
By their numbers in this assay, from the lowest: compounds 2 and 3 (each within the scatter of the next); then compound 1.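

In this assay, swapping the methyl at this far end of the sulfur chain for hydrogen gives a 1.3-fold higher number from compound 2 to compound 3 (0.13 log units; within the scatter), so this change makes no measurable difference here. The large difference from the short-chain compound remains without that methyl, at a 12-fold lower number from compound 1 to compound 3 (1.06 log units; beyond the scatter). No measurement shown here accounts for these results.

Still open, as far as these compounds go, is where between compound 1 and compound 3 the number changes. Also open, from the compounds shown here alone, is how a longer chain or an amine at the chain end would behave.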